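Series notes: the step from compound 2 to compound 3

The compounds below may be only part of what the source reports. "The series", "measured", "known", "first", "only" and "open" are said of these compounds alone.

Measured so far:
compound 1 `O=c1cc(/C=N\O)c2ccc(OCc3ccccc3)cc2o1` — in a functional assay, read by spectrophotometry, with a stated time of 3 min (on this read-out higher numbers stand for weaker inhibition and lower numbers for stronger inhibition), compound 1 gives 22800 nM
compound 2 `N/N=C\c1cc(=O)oc2cc(OCc3ccccc3)ccc12` — in this assay compound 2 gives 9740 nM

For the measured compounds named here, compound 2 stands lowest of the two numbers; its nearest neighbour is compound 1, and the only measured step, a 2.3-fold lower number from compound 1 to compound 2 (0.37 log units; beyond the scatter), concerns amino in place of hydroxy on a double-bonded nitrogen. Compound 3 `O=c1cc(-c2nc3ccccc3[nH]2)c2ccc(OCc3ccccc3)cc2o1` differs from compound 2 by a group of 9 heavy atoms (7 carbon, 2 nitrogen; one five-membered aromatic ring with 2 hetero atoms, one six-membered aromatic ring of carbon only) in place of a group of 3 heavy atoms (1 carbon, 2 nitrogen; no ring), on an aromatic carbon. Going by the values given here, no measured step bears on this change: the one step known covers a small exchange on the double-bonded nitrogen, whereas here the whole group is replaced by two aromatic rings. The expectation in this assay therefore rests on little; a step of the size seen so far, in either direction, or none beyond the scatter, is all plausible. Compound 3 is estimated at 6000 nM (range 1500 nM to 30000 nM), which would mean an expected 1.6-fold lower number from compound 2 to compound 3 (0.21 log units; within the scatter).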

Compound 3, half-maximal inhibitory concentration: "not active" (no number reported)
Compound 3 has no reported number here, so the estimate cannot be set against anything.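

In this assay, for the compounds shown here, compound 3 is recorded as "not active" without a number, so no step from compound 2 to compound 3 can be read. The compounds shown leave open how far 1H-benzimidazol-2-yl at this place shifts the number. No supporting data bear on this result.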